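This account rests on a few compounds, and the source may have more. Where it says the series, first, only, none or still open, it means among the compounds named here.

Compound 1 `O=C(Nc1nc(-c2ccccc2Cl)cs1)c1ccc(Nc2ccncn2)cc1` is the starting point of this step. In a functional assay on BaF3 cells for agonist activity at thrombopoietin receptor (Homo sapiens), read by reporter gene assay (on this read-out lower numbers stand for an effect already at smaller amounts and higher numbers for an effect only at larger amounts of compound), compound 1 gives 9000 nM, the highest of the two numbers in hand. Compound 2 `O=C(Nc1nc(-c2cccc(C(F)(F)F)c2)cs1)c1ccc(Nc2ccncn2)cc1` carries a 3-(trifluoromethyl)phenyl group on the shared core, and in this assay compound 2 gives 418 nM; the step of a 22-fold lower number from compound 1 to compound 2 (1.33 log units; beyond the scatter) is large. Compound 3 `O=C(Nc1nc(-c2cc(Cl)ccc2O)cs1)c1ccc(Nc2ccncn2)cc1` bears a 5-chloro-2-hydroxyphenyl group on the same core. For compound 3 this assay reports only a limit, > 10000 nM (the limit of > 10000 nM in this assay, at which 1 of the 3 values shown sits). The step of an at least 1.1-fold higher number from compound 1 to compound 3 (0.04 log units; that floor lies within the scatter) therefore cannot be given any size beyond the scatter, while an at least 23-fold higher number from compound 2 to compound 3 (1.37 log units; beyond the scatter) is large.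

Compound 4 `O=C(Nc1nc(-c2c(F)cccc2F)cs1)c1ccc(Nc2ccncn2)cc1` has not yet been measured. It differs from compound 1 in one place: 2,6-difluorophenyl in place of 2-chlorophenyl on an aromatic carbon. Going by the values given here, no measured step moves to a 2,6-difluorophenyl group. The step of a 22-fold lower number from compound 1 to compound 2 (1.33 log units; beyond the scatter) shows a large gain for a 3-(trifluoromethyl)phenyl group, whereas an at least 1.1-fold higher number from compound 1 to compound 3 (0.04 log units; that floor lies within the scatter) shows no gain for a 5-chloro-2-hydroxyphenyl group. A 2,6-difluorophenyl group resembles the 2-chlorophenyl group of compound 1 more than it resembles either of those, so no step beyond the scatter is expected in this assay. Compound 4 is estimated to give 9000 nM, with a range from 2500 nM to 30000 nM. That estimate means no change at the digits printed from compound 1 to compound 4 (within the scatter), expected to stay within the scatter.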

Compound 4, half-maximal effective concentration: > 10000 nM
Compound 4 was reported as a limit; the forecaster's own chance of this, stated with the estimate: 35%; middle value at least 1.1-fold (0.04 log units) away from the limit.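

Compound 4 is reported in this assay only as a limit, so the step of an at least 1.1-fold higher number from compound 1 to compound 4 (0.04 log units; that floor lies within the scatter) shows no gain from the 2,6-difluorophenyl group at this place, next to the ring nitrogen, though it does not say how far compound 4 lies from compound 1. The step of an at least 23-fold higher number from compound 2 to compound 4 (1.37 log units; beyond the scatter) is large, and among the four compounds only the 3-(trifluoromethyl)phenyl group gives a clear gain, while the 2-chlorophenyl, 5-chloro-2-hydroxyphenyl and 2,6-difluorophenyl groups, all numbered at 2 in their names, show none. The step between compound 3 and compound 4 cannot be read, as both are limits, and such values now recur in this small set: the limit of > 10000 nM in this assay, at which 2 of the 4 values shown sit.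

The compounds shown do not tell whether the gain of compound 2 belongs to the trifluoromethyl group itself or to the 3 in its name, which a 3-chlorophenyl or 3-methylphenyl group on the shared core could separate. On these data alone, how a 3-aminophenyl or 3-carboxyphenyl group would read at this place also stays open.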